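Working notes: the step from compound 2 to compound 3

The source may hold more compounds than are shown below. What is called first, only, known or untested is meant among the compounds shown, and "the series" means these compounds.

Among the compounds with values here, in a functional assay on MCF7 cells (Homo sapiens) for antiproliferative activity, read by MTT assay, with a stated time of 48 h (on this read-out lower numbers stand for stronger inhibition and higher numbers for weaker inhibition), compound 1 `CC(C)=CCC[C@]1(C)/C=C/[C@@H](OC(=O)C=C(C)C)[C@](C)(O)/C=C/C(=O)/C(C=O)=C\C1` gives 12600 nM and compound 2 `CSC(=S)OC/C1=C/C[C@](C)(CCC=C(C)C)/C=C/[C@@H](OC(=O)C=C(C)C)[C@](C)(O)/C=C/C1=O` gives 900 nM, the lower of the two numbers so far. Within the data shown here, the only measured step, a 14-fold lower number from compound 1 to compound 2 (1.15 log units; beyond the scatter), is large and beyond the scatter, and it involves a group on a double-bonded ring carbon. Compound 3 `CO/N=C/C1=C/C[C@](C)(CCC=C(C)C)/C=C/[C@@H](OC(=O)C=C(C)C)[C@](C)(O)/C=C/C1=O` changes the group on that same carbon: a group of 4 heavy atoms (2 carbon, 1 nitrogen, 1 oxygen; no ring) in place of a group of 6 heavy atoms (3 carbon, 1 oxygen, 2 sulfur; no ring), on a double-bonded ring carbon. The entering group matches neither group measured there, so this single step gives a span, not a rule. With compound 2 at the low end of that span at 900 nM, a moderate move to a higher number in this assay is expected, smaller than a 14-fold lower number from compound 1 to compound 2 (1.15 log units; beyond the scatter). The expected step is a 3.3-fold higher number from compound 2 to compound 3 (0.52 log units; beyond the scatter). The estimate for compound 3 is 3000 nM, with an expected range of 800 nM to 11000 nM.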

Compound 3, half-maximal inhibitory concentration: 2510 nM
For compound 3 the middle estimate is 1.2-fold (0.08 log units) above the measured one; the range from low to high includes it.
By their numbers in this assay, from the lowest: compound 2; then compound 3; then compound 1.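

Placing the entering group on this double-bonded ring carbon gives a 2.8-fold higher number from compound 2 to compound 3 (0.45 log units; beyond the scatter) and a 5.0-fold lower number from compound 1 to compound 3 (0.70 log units; beyond the scatter) in this assay, so the lower number seen with compound 2 does not depend on keeping its sulfur-bearing group. Across compound 1, compound 3 and compound 2, the number falls as the heavy-atom count of the group at this carbon rises, though that order rests on these three compounds alone, and the atoms change along with the count. Nothing available explains the differences among these groups.

From the compounds shown here alone, it remains open whether the order would hold for a longer chain on the oxygen of the entering group. A carboxylic acid or an amine at this carbon would test whether the order follows group size or the atoms present.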